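Swapping an Ester Tail: Propanoyl to Benzoyl

The compounds below may be only part of what the source reports. "The series", "measured", "known", "first", "only" and "open" are said of these compounds alone.

The measured compounds, one by one:
Compound 1 `CCCSc1nc(N[C@@H]2C[C@H]2c2ccc(F)c(F)c2)c2nnn([C@@H]3C[C@H](OC(C)=O)[C@@H](O)[C@H]3O)c2n1` has in a functional assay on the whole organism (strain Sprague-Dawley) for inhibition, with Rattus norvegicus as the target, with a stated time of 0.5 h, at a dose of 5 mg/kg by the oral route; a lower number here means less inhibition, a higher number more inhibition at the dose given (going by the name of the read-out) "not determined" (no result reported).
Compound 2 `CCCSc1nc(N[C@@H]2C[C@H]2c2ccc(F)c(F)c2)c2nnn([C@@H]3C[C@H](OCCOC(=O)OCC)[C@@H](O)[C@H]3O)c2n1` gives in this assay 47.7%.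
Compound 3 `CCCSc1nc(N[C@@H]2C[C@H]2c2ccc(F)c(F)c2)c2nnn([C@@H]3C[C@H](OC(=O)CC)[C@@H](O)[C@H]3O)c2n1` gives in this assay 44.5%.

All three share a core and differ only in the group carried on an oxygen on a saturated carbon of the sugar-like ring. Compound 3 stands with the lowest of the two numbers recorded, but its nearest neighbour is compound 2, and the step of a number 3.2 percentage points lower from compound 2 to compound 3 (within the scatter) falls within the scatter, so the two cannot be told apart on these figures. Compound 1 adds nothing, as it has no reported number.

Compound 4 `CCCSc1nc(N[C@@H]2C[C@H]2c2ccc(F)c(F)c2)c2nnn([C@@H]3C[C@H](OC(=O)c4ccccc4)[C@@H](O)[C@H]3O)c2n1` is the next step from compound 3: phenyl in place of ethyl on a carbonyl carbon. For the measured compounds named here, the only measured step, from compound 2 to compound 3, also altered the group on that same oxygen, and it changed nothing beyond the scatter. Going by the values given here, no measured pair exchanges an alkyl for an aromatic ring on a carbonyl carbon, so the comparison is indirect. On this thin record, the expectation for compound 4 in this assay is a step of about a number 0.5 percentage points higher from compound 3 to compound 4 (within the scatter), that is, no movement beyond the scatter. Compound 4 is therefore estimated at 45%, with a range from 25% to 65%.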

Compound 4, a percentage reported as inhibition, in the whole organism at one dose (the size of the read-out at that dose, not a potency): 20.1%
The estimate for compound 4 lay 24.9 percentage points above the measured number, and the stated range ends above it.
By their numbers in this assay, from the lowest: compound 4; then compounds 3 and 2 (each within the scatter of the next).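

For the compounds shown here, the step from ethyl to phenyl shows that the group on this carbonyl carbon is not a free choice: in this assay, the exchange gives a number 24.4 percentage points lower from compound 3 to compound 4 (beyond the scatter) and is the first change at this oxygen to go beyond the scatter. The comparison with the carbonate-bearing chain of compound 2 points the same way, with a number 27.6 percentage points lower from compound 2 to compound 4 (beyond the scatter) even though the printed heavy-atom count of the group on the oxygen is the same on both sides, so among these compounds that count does not track the read-out. What sets the benzoyl ester apart remains unexplained, as nothing measured here bears on the reason for this drop.

The compounds shown cannot separate the aromatic ring itself from the larger group on the carbonyl carbon, a question that a cyclohexyl group, a saturated six-membered ring of carbon, could help to settle. On these data alone, it also remains open how a longer chain such as butyl would behave there, and whether an amine on the phenyl ring would change the outcome.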